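The source may report more compounds than this note shows. Statements on the series, on what has been measured and on what is new or still open speak of the compounds shown alone.

Of the compounds shown here, three built on one shared core have been measured in an assay on CHO cells for displacement of a labelled ligand from adenosine receptor A3 (Homo sapiens), read by scintillation counting, with a stated time of 120 min, tested at 10 uM; on this read-out higher numbers stand for more inhibition at the one concentration tested (going by the name of the read-out) and lower numbers for less inhibition. Compound 3 `Nc1scc(CN2CCN(c3ccc(OC(F)(F)F)cc3)CC2)c1C(=O)c1ccc(Cl)cc1` gives 1% in this assay, compound 1 `Nc1scc(CN2CCN(c3ccc(Cl)cc3Cl)CC2)c1C(=O)c1ccc(Cl)cc1` gives 0% and compound 2 `Nc1scc(CN2CCN(c3ccc(F)cc3Cl)CC2)c1C(=O)c1ccc(Cl)cc1` gives 0%. Within the data shown here, compound 3 holds the highest of the three numbers, but its nearest neighbour is compound 1, with a number 1 percentage points higher from compound 1 to compound 3 (within the scatter), and its furthest is compound 2, with a number 1 percentage points higher from compound 2 to compound 3 (within the scatter); no pair among the three is separated beyond the scatter.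

Compound 4 `Nc1scc(CN2CCN(c3cccc(F)c3)CC2)c1C(=O)c1ccc(Cl)cc1` has not yet been measured. Its difference from compound 3 is 3-fluorophenyl in place of 4-(trifluoromethoxy)phenyl on an amine nitrogen in a ring. The measured steps that bear on this change are those that also replace the group on the amine nitrogen in a ring: a number 1 percentage points higher from compound 1 to compound 3 (within the scatter) and a number 1 percentage points higher from compound 2 to compound 3 (within the scatter), both within the scatter. The step of no change at the digits printed from compound 1 to compound 2 (within the scatter), fluoro in place of chloro on an aromatic carbon, likewise showed nothing. Among the measured compounds there is no sign that a different group on this nitrogen moves the read-out, so the step expected from compound 3 to compound 4, no change at the digits printed from compound 3 to compound 4 (within the scatter), is none beyond the scatter. Compound 4 is therefore estimated to give 1% in this assay, within a range from -5% to 10%.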

Compound 4, a percentage reported as inhibition, at one concentration (the size of the read-out at that concentration, not a potency): 4%
The estimate for compound 4 lay 3 percentage points below the measured number, within the range that was stated.
By their numbers in this assay, from the lowest: compounds 1, 2, 3 and 4 (each within the scatter of the next).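

In this assay, among these compounds, the step of a number 3 percentage points higher from compound 3 to compound 4 (within the scatter) stands together with a number 4 percentage points higher from compound 2 to compound 4 (within the scatter) and a number 4 percentage points higher from compound 1 to compound 4 (within the scatter) as the first evidence on 3-fluorophenyl at this position. The group that enters has fewer heavy atoms than 4-(trifluoromethoxy)phenyl and no hydrogen-bond acceptor, yet the read-out stays within the scatter of each of the three earlier compounds, so the flat picture on the amine nitrogen now holds for four different aryl groups and for this loss of the acceptor. No measured evidence is available here to explain this result.

All four groups on this nitrogen are phenyl rings bearing halogen or trifluoromethoxy, so the compounds shown leave open whether an amine, a carboxylic acid or a longer chain at this place would lift the number clear of the scatter in this assay. They also share everything else in the core, which leaves open whether a change elsewhere, such as an amide in place of the free amine on the shared core, would move the read-out at all.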